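The source may report more compounds than this note shows. Statements on the series, on what has been measured and on what is new or still open speak of the compounds shown alone.

Measured in an assay on isolated protein for inhibition of Calpain-1 catalytic subunit (Sus scrofa); a higher number here means a weaker inhibitor, a lower number a stronger inhibitor:

Compound 1, `O=C(O)/C(S)=C/c1cccc(F)c1`, gives 31500 nM.
Compound 2, `O=C(O)/C(S)=C/c1c[nH]c2cccc(F)c12`, gives 300 nM.
Compound 3, `O=C(O)/C(S)=C/c1c[nH]c2ccc(I)cc12`, gives 90 nM.

Among these three, compound 1 has the highest number and is thus the weakest inhibitor of the set; compound 2 stands nearest to it and compound 3 furthest, both gaps lying well beyond the scatter. Compounds 2 and 3 carry a different core from compound 1, so no single change connects them to it. Compound 4, `O=C(O)/C(S)=C/c1cccc(Br)c1`, keeps the core of compound 1 and alters one group: bromo in place of fluoro on an aromatic carbon. Within the data shown here, no pair of measured compounds shows bromo in place of fluoro, so there is nothing to gauge this swap against. Such a swap is expected to shift the number only a little, if at all beyond the scatter, with a slight lean toward a lower number. Compound 4 is therefore estimated at about 20000 nM, with a likely range from 7000 nM to 55000 nM. That estimate corresponds to a step of a 1.6-fold lower number from compound 1 to compound 4 (0.20 log units; within the scatter), which is expected to be small.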

Compound 4, half-maximal inhibitory concentration: 8400 nM
Compound 4: the middle estimate sits 2.4-fold (0.38 log units) above what was measured, within the range that was stated.
By their numbers in this assay, from the lowest: compound 3; then compound 2; then compound 4; then compound 1.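

Bromo in place of fluoro on an aromatic carbon brings a 3.8-fold lower number from compound 1 to compound 4 (0.57 log units; beyond the scatter) in this assay and so shows that the number responds to which halogen sits at this place on the six-membered ring. Among these compounds, this is the first step in the set that changes one group while the core stays fixed, so it can be read directly, unlike the gaps to compounds 2 and 3. The swap exchanges one heavy atom for one heavy atom and leaves the counts of hydrogen-bond donors and acceptors at zero, and nothing available here accounts for the lower number.

Going by these compounds, whether chloro, methoxy or an amine at this same place would lower the number further stays open, since one step between two halogens sets no trend. Also open, on these data alone, is whether this swap would give a similar step on the core of compound 2.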